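This account rests on a few compounds, and the source may have more. Where it says the series, first, only, none or still open, it means among the compounds named here.

Measured so far in an assay on cells for binding affinity to Neuropeptide Y receptor type 1 (Homo sapiens); a lower number here means a stronger inhibitor, a higher number a weaker inhibitor:
compound 1, `CCOc1cc(CCc2nc(C)c(CC)s2)nc(NCc2cc(Cl)cc(NC(=O)OC(C)C)c2)c1`: 33 nM
compound 2, `CCCCOc1cc(CCc2nc(C)c(CC)s2)nc(NCc2cc(Cl)cc(NC(=O)OC(C)C)c2)c1`: 16 nM
compound 3, `CCc1sc(CCc2cc(OC(CC)CC)cc(NCc3cc(Cl)cc(NC(=O)OC(C)C)c3)n2)nc1C`: 5.5 nM

Compound 3 stands lowest of the three numbers; both a 2.9-fold lower number from compound 2 to compound 3 (0.46 log units; beyond the scatter) and a 6.0-fold lower number from compound 1 to compound 3 (0.78 log units; beyond the scatter) are beyond the scatter. Compound 4, `CCc1sc(CCc2cc(OC3CCCCC3)cc(NCc3cc(Cl)cc(NC(=O)OC(C)C)c3)n2)nc1C`, differs from compound 3 by cyclohexyl in place of pentan-3-yl on an oxygen on an aromatic ring. Going by the values given here, no measured step replaces a branched chain by a ring on that oxygen, but the three measured steps all enlarge the group on the same oxygen and all point the same way: a 2.1-fold lower number from compound 1 to compound 2 (0.31 log units; beyond the scatter), a 6.0-fold lower number from compound 1 to compound 3 (0.78 log units; beyond the scatter) and a 2.9-fold lower number from compound 2 to compound 3 (0.46 log units; beyond the scatter), each modest. The expected step is therefore small, toward a lower number or none beyond the scatter, a 1.4-fold lower number from compound 3 to compound 4 (0.14 log units; within the scatter). Compound 4 is estimated at 4 nM, within a range of 1.5 nM to 12 nM.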

Compound 4, half-maximal inhibitory concentration: 29 nM
Compound 4: middle estimate off by 7.3-fold (0.86 log units), on the low side, outside the stated range (above it).
By their numbers in this assay, from the lowest: compound 3; then compounds 2, 4 and 1 (each within the scatter of the next, the first and the last beyond it).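

On the oxygen on the aromatic ring, a larger group did not keep lowering the number: cyclohexyl undid the gain seen with pentan-3-yl (a 5.3-fold higher number from compound 3 to compound 4 (0.72 log units; beyond the scatter)), so the branched chain and the ring are not interchangeable at this position. Cyclohexyl stands within the scatter of both butyl (a 1.8-fold higher number from compound 2 to compound 4 (0.26 log units; within the scatter)) and ethyl (a 1.1-fold lower number from compound 1 to compound 4 (0.06 log units; within the scatter)), keeping none of the advantage of compound 3. Nothing available explains this difference. How cyclopentyl, isopropyl or tetrahydropyran-4-yl would compare on this oxygen remains open, so the shown compounds cannot separate the effect of branching from that of ring closure.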